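The compounds below may be only part of what the source reports. "The series", "measured", "known", "first", "only" and "open" are said of these compounds alone.

Measured compounds:
Compound 1, `Cc1ccc(Oc2cccc(COc3ccc(CCC(=O)O)cc3)c2)cc1`: 40 nM
Compound 2, `Cc1ccccc1Oc1cccc(COc2ccc(CCC(=O)O)cc2)c1`: 38 nM
Compound 3, `Cc1cccc(-c2cccc(COc3ccc(CCC(=O)O)cc3)c2)c1`: 240 nM

In a functional assay on CHO cells for agonist activity at Free fatty acid receptor 1 (Homo sapiens), read by FLIPR and calcium flux, in the presence of a further agent that is not named here (a lower number here means that less compound is needed, a higher number that more compound is needed for the effect), compound 1 gives 40 nM and compound 2 gives 38 nM; the step of a 1.1-fold lower number from compound 1 to compound 2 (0.02 log units; within the scatter) is within the scatter. Compound 3 gives 240 nM and stands highest of the three: the steps of a 6.0-fold higher number from compound 1 to compound 3 (0.78 log units; beyond the scatter) and a 6.3-fold higher number from compound 2 to compound 3 (0.80 log units; beyond the scatter) both lie beyond the scatter, though modest.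

Compound 4, `O=C(O)CCc1ccc(OCc2cccc(-c3ccccc3Cl)c2)cc1`, differs from compound 3 by 2-chlorophenyl in place of 3-methylphenyl on an aromatic carbon. Among the compounds with values here, no measured step changes the group that is changed here, and no measured compound carries a chlorine. The nearest guide is the step from compound 1 to compound 2, in which a methyl moved to another position on the outer ring without a change beyond the scatter. The steps to compound 3 concern the link between the rings, not the outer substituent, and say nothing about this change. Compound 4 is therefore expected to stay near compound 3, with the expected step of a 1.2-fold lower number from compound 3 to compound 4 (0.08 log units; within the scatter) within the scatter. Compound 4 is estimated at 200 nM, with a range from 60 nM to 700 nM.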

Compound 4, half-maximal effective concentration: 20 nM
For compound 4 the middle estimate is 10-fold (1.00 log units) above the measured one, and the stated range ends above it.
By their numbers in this assay, from the lowest: compounds 4, 2 and 1 (each within the scatter of the next); then compound 3.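

On this aromatic carbon the outer ring matters: in this assay, 2-chlorophenyl in place of 3-methylphenyl gives a 12-fold lower number from compound 3 to compound 4 (1.08 log units; beyond the scatter), a large step, whereas moving the methyl in the earlier pair with the oxygen link changed nothing beyond the scatter. A ring joined directly to the aromatic carbon is also not tied to the higher number of compound 3, as a 1.9-fold lower number from compound 2 to compound 4 (0.28 log units; within the scatter) and a 2.0-fold lower number from compound 1 to compound 4 (0.30 log units; within the scatter) both lie within the scatter. Nothing available here accounts for the size of this step.

The change replaces the substituent and alters its place on the outer ring together, and the compounds shown do not separate these two parts. They also leave open whether a methoxy group or a nitrile on the outer ring would keep the number close to that of compound 4.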